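A few compounds are considered here, and "the series" means these few. Any claim that something is new, unique, unknown or untested is made for them only; others in the source may bear on it.

Compound 1 (`CNc1nc(Cl)nc2c1ncn2[C@H]1C[C@H](N=[N+]=[N-])[C@@H](CO)O1`) was tested in an ADME assay on Vero cells (Chlorocebus sabaeus) for cytotoxicity, with a stated time of 5 days (on this read-out higher numbers stand for weaker inhibition and lower numbers for stronger inhibition), alongside compound 2 (`COc1nc(F)nc2c1ncn2[C@H]1C[C@H](N=[N+]=[N-])[C@@H](CO)O1`). In this assay compound 1 gives > 100000 nM, which is a limit of the assay and not a number. Compound 2 gives > 100000 nM in this assay, and this too is a limit. Going by the values given here, compound 1 therefore stands with the only other measured compound, as the limit of > 100000 nM in this assay, at which 2 of the 2 values shown sit, records, and no exact value is available for either.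

The next compound is compound 3 (`[N-]=[N+]=N[C@H]1C[C@H](n2cnc3c(N)nc(Cl)nc32)O[C@@H]1CO`), which keeps the core of compound 1 but has hydrogen in place of methyl on a nitrogen on an aromatic ring, turning methylamino to amino: hydrogen in place of methyl on a nitrogen on an aromatic ring. Among the compounds with values here, no measured pair shows what this change does in this assay, so any expectation is uncertain. Little change beyond the scatter is expected, with any shift more likely towards stronger inhibition, since compound 1 starts from > 100000 nM. The expected change is a number no higher from compound 1 to compound 3 (the limit leaves the size open), which is only an estimate. For compound 3 the expected value is 100000 nM, with an estimated range of 30000 nM to 300000 nM.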

Compound 3, half-maximal inhibitory concentration: > 100000 nM
Compound 3 was reported as a limit (the forecaster's own chance of this, stated with the estimate: 70%); the middle value sits exactly at the limit.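

In this assay compound 3 gives > 100000 nM, which is a limit of the assay and not a number. Compound 1 also stands at a limit, so no step can be read between compound 1 and compound 3, and all compounds shown share one record: the limit of > 100000 nM in this assay, at which 3 of the 3 values shown sit. The compounds shown leave open what the change from methylamino to amino does in this assay, and where any exact value lies.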